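Moving the fluorine on the anilino ring of compound 3

The source may hold more compounds than are shown below. What is called first, only, known or untested is meant among the compounds shown, and "the series" means these compounds.

Three compounds share a common core, and in a functional assay on MGC-803 cells (Homo sapiens) for inhibition, read by MTT assay, with a stated time of 72 h (on this read-out lower numbers stand for stronger inhibition and higher numbers for weaker inhibition), they spread over a modest range. Compound 1 `N#Cc1c(Nc2ccc(Cl)cc2)nc(SCc2cn(Cc3ccccc3Cl)nn2)nc1-c1ccccc1` gives 5850 nM, compound 2 `N#Cc1c(Nc2cccc([N+](=O)[O-])c2)nc(SCc2cn(Cc3ccccc3Cl)nn2)nc1-c1ccccc1` gives 43100 nM, and compound 3 `N#Cc1c(Nc2ccccc2F)nc(SCc2cn(Cc3ccccc3Cl)nn2)nc1-c1ccccc1` gives 7580 nM, the second highest of the three numbers. The nearest neighbour of compound 3 is compound 1: a 1.3-fold higher number from compound 1 to compound 3 (0.11 log units; within the scatter). The farthest is compound 2: a 5.7-fold lower number from compound 2 to compound 3 (0.75 log units; beyond the scatter). Compound 4 `N#Cc1c(Nc2ccc(F)cc2)nc(SCc2cn(Cc3ccccc3Cl)nn2)nc1-c1ccccc1` differs from compound 3 by 4-fluorophenyl in place of 2-fluorophenyl on a nitrogen on an aromatic ring. For the measured compounds named here, no measured step rearranges the same group; the closest comparison is the step from the 4-chlorophenyl compound to compound 3, which stays within the scatter. Compound 4 is therefore expected to sit close to compound 3, with a 1.2-fold lower number from compound 3 to compound 4 (0.07 log units; within the scatter), giving an estimate of 6500 nM within 3000 nM to 15000 nM in this assay.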

Compound 4, half-maximal inhibitory concentration: 8740 nM
Compound 4: the middle estimate sits 1.3-fold (0.13 log units) below what was measured; measured number inside the range.
By their numbers in this assay, from the lowest: compounds 1, 3 and 4 (each within the scatter of the next); then compound 2.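

In this assay the change from (2-fluorophenyl)amino to (4-fluorophenyl)amino gives a 1.2-fold higher number from compound 3 to compound 4 (0.06 log units; within the scatter), so rearranging the same atoms leaves the number within the scatter. Fluoro in place of chloro on an aromatic carbon gives a 1.5-fold higher number from compound 1 to compound 4 (0.17 log units; within the scatter), also within the scatter, while 4-fluorophenyl in place of 3-nitrophenyl gives a 4.9-fold lower number from compound 2 to compound 4 (0.69 log units; beyond the scatter), leaving compound 2 alone apart from the halogen-bearing compounds shown.

No evidence is available to explain these results. As far as these compounds go, it remains open whether a 4-aminophenyl or 4-carboxyphenyl group on this nitrogen would stay with the halogen-bearing compounds or move toward compound 2.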